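A few compounds are considered here, and "the series" means these few. Any claim that something is new, unique, unknown or untested is made for them only; others in the source may bear on it.

Measured so far:
- compound 1 `O=C(NCc1ccco1)c1ccccc1OCc1ccccc1`: 49000 nM
- compound 2 `O=C(Nc1cccnc1)c1ccccc1OCc1ccccc1C(F)(F)F`: 2100 nM
- compound 3 `N#Cc1ccccc1COc1ccccc1C(=O)Nc1cccnc1`: 31800 nM

In an assay on lysate for inhibition of phosphatidylcholine:ceramide cholinephosphotransferase 2 (Homo sapiens), read by HPLC, with stated times of 30 min and 2 h (on this read-out higher numbers stand for weaker inhibition and lower numbers for stronger inhibition), compound 3 gives 31800 nM, the second highest of the three numbers. Its nearest neighbour is compound 1, which gives 49000 nM in this assay, a gap within the scatter, so the two cannot be told apart. Within the data shown here, its most distant neighbour is compound 2 with 2100 nM, and the step of a 15-fold higher number from compound 2 to compound 3 (1.18 log units; beyond the scatter) is the one measured step that bears on what comes next: exchanging trifluoromethyl for cyano on the aromatic carbon moved the number sharply upward.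

Compound 4 `O=C(Nc1cccnc1)c1ccccc1OCc1cc(Cl)ccc1Cl` differs from compound 3 in the change (2,5-dichlorophenyl in place of 2-cyanophenyl on a saturated chain carbon bound to an oxygen on an aromatic ring). Among the measured compounds shown here, since the measured step from compound 2 to compound 3 shows that leaving the trifluoromethyl-bearing ring for the cyano-bearing ring cost a large amount, and compound 4 now leaves the cyano-bearing ring for a halogen-bearing one, the expected direction is back downward, roughly reversing that step, though with wide uncertainty because no dichlorophenyl compound has been measured. The expected step is a 9.1-fold lower number from compound 3 to compound 4 (0.96 log units; beyond the scatter), and compound 4 is estimated at 3500 nM, within 800 nM to 15000 nM.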

Compound 4, half-maximal inhibitory concentration: 990 nM
Estimate against measurement, compound 4: 3.5-fold (0.55 log units) above; low and high end bracket the measured number.
By their numbers in this assay, from the lowest: compound 4; then compound 2; then compounds 3 and 1 (each within the scatter of the next).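

The swap of 2-cyanophenyl for 2,5-dichlorophenyl on the saturated chain carbon bound to an oxygen on an aromatic ring gives a 32-fold lower number from compound 3 to compound 4 (1.51 log units; beyond the scatter) and so shows that this position responds strongly to what its ring carries, even though both groups hold 8 heavy atoms. The earlier step, a 15-fold higher number from compound 2 to compound 3 (1.18 log units; beyond the scatter), rested on a single pair, whereas now two different groups, in compound 2 and compound 4, each give a far lower number than the nitrile-bearing compound 3. No measurement at hand explains why this exchange has so large an effect.

On these data alone, it remains open whether a ring with a single chlorine would hold the number as low, or how a methoxy group or an amine on that ring would behave. As far as these compounds go, it is also open whether 2,5-dichlorophenyl would lower the number as far on the core of compound 1.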